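Swapping the Amide Nitrogen Substituent in a Sulfonamide Series

The source may hold more compounds than are shown below. What is called first, only, known or untested is meant among the compounds shown, and "the series" means these compounds.

Compound 1, `CC(C)N1C(=O)COc2ccc(-c3cccc(NS(=O)(=O)c4ccc(F)cc4)c3)cc21`: 22700 nM
Compound 2, `O=C1COc2ccc(-c3cccc(NS(=O)(=O)c4ccc(F)cc4)c3)cc2N1c1ccc(Cl)cc1`: 35000 nM
Compound 3, `COc1ncc(-c2ccc3c(c2)N(c2ccc(Cl)cc2)C(=O)CO3)cc1NS(=O)(=O)c1ccc(F)cc1`: 4830 nM

All three compounds were tested in a functional assay on HeLa cells (Homo sapiens) for antiproliferative activity, read by MTT assay, with a stated time of 72 h; a lower number here means a stronger inhibitor, a higher number a weaker inhibitor. Compound 3 gives the lowest number of the three; compound 1 gives a higher number and compound 2 a higher one still, and both gaps lie beyond the scatter. Compound 1 and compound 2 share one core, while compound 3 carries another; the difference between the two cores is not broken down here. Within the shared core of compound 1 and compound 2, the two differ in one place only: isopropyl in place of 4-chlorophenyl on an amide-type nitrogen in a ring. This change gave a 1.5-fold lower number from compound 2 to compound 1 (0.19 log units; within the scatter).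

Compound 4, `COc1ncc(-c2ccc3c(c2)N(C(C)C)C(=O)CO3)cc1NS(=O)(=O)c1ccc(F)cc1`, has not yet been measured in this assay. It stands to compound 3 exactly as compound 1 stands to compound 2, the change being (isopropyl in place of 4-chlorophenyl on an amide-type nitrogen in a ring), the same change at the same place. Among the measured compounds shown here, the expectation for compound 4 rests on the one measured instance of this change, which gave a 1.5-fold lower number from compound 2 to compound 1 (0.19 log units; within the scatter), so compound 4 is expected to move from compound 3 by a 1.4-fold lower number from compound 3 to compound 4 (0.14 log units; within the scatter). Compound 4 is therefore estimated at 3500 nM, with a likely range from 1200 nM to 10000 nM.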

Compound 4, half-maximal inhibitory concentration: 2790 nM
Compound 4: middle estimate off by 1.3-fold (0.10 log units), on the high side, within the range that was stated.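

In this assay, isopropyl in place of 4-chlorophenyl on the amide-type nitrogen gave a 1.7-fold lower number from compound 3 to compound 4 (0.24 log units; within the scatter), and the step on the second core matches the one on the first within the scatter: the same change on two cores in this assay, a 1.5-fold lower number (0.19 log units; within the scatter) from compound 2 to compound 1 and a 1.7-fold lower number (0.24 log units; within the scatter) from compound 3 to compound 4, 1.1-fold (0.05 log units) apart, within the scatter of two such steps

Within this series, the change therefore carries from one core to the other without a measurable difference in its size, and on neither core does it move the number beyond the scatter. This does not show that the change would behave the same way on any further core, since the comparison rests on just two pairs, and it says nothing about why the two steps agree.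

The compounds shown leave open whether other groups on this nitrogen, such as a longer chain, an amine or a carboxylic acid, would also leave the number within the scatter. They also leave open which part of the difference between the two cores matters in this assay.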